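Compound 2 to compound 4: methoxy for methoxymethyl

This account rests on a few compounds, and the source may have more. Where it says the series, first, only, none or still open, it means among the compounds named here.

- compound 1 `COCc1ccccc1C1CCc2nc[nH]c2C1` gives 2.2; 2.2 (2 entries)
- compound 2 `COCc1ccccc1C1Cc2nccn2C1` gives 1.8
- compound 3 `COc1cccc(C2CCc3nc[nH]c3C2)c1` gives 2.6

In a physicochemical assay for lipophilicity, at pH 7.4 (a lower number here means a more polar compound, a higher number a more lipophilic compound), compound 2 (1.8) is the lowest of the two single numbers, and compound 3 (2.6) lies above it, beyond the scatter. Compound 1 (2.2; 2.2 (2 entries)), with its two entries, also lies above compound 2.

Compound 4 `COc1ccccc1C1Cc2nccn2C1` is not yet measured. It departs from compound 2 by methoxy in place of methoxymethyl on an aromatic carbon with methoxy in place of methoxymethyl on an aromatic carbon.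

Within the data shown here, no pair of measured compounds differs in one place only, so the expectation rests on weak evidence. Compound 3 (2.6) carries methoxy and compound 1 (2.2; 2.2 (2 entries)) carries methoxymethyl. Of these two, compound 3 stands higher, but that pair differs in more than one place. A small upward shift in this assay is therefore expected, and it may not clear the scatter. The estimated step is a number 0.30 log units higher from compound 2 to compound 4 (within the scatter) in this series. Compound 4 is expected at 2.1 with an estimated range from 1.7 to 2.5 in these notes.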

Compound 4, distribution coefficient: 1.9
Beside the measured number, compound 4's estimate is 0.20 log units above it; measured number inside the range.
By their numbers in this assay, from the lowest: compounds 2 and 4 (each within the scatter of the next); then compound 3.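

In this assay, the series now has a direct reading of methoxy in place of methoxymethyl on an aromatic carbon, ortho to a group of 8 heavy atoms: a number 0.10 log units higher from compound 2 to compound 4 (within the scatter). At this position and on this core, the change therefore does not separate from the scatter, something the values of compound 1 and compound 3 could not show, as those compounds differ in more than one place. No measurement is at hand that speaks to the reason for this result.

The compounds shown leave open whether the same change gives a similar step on the core of compound 1. They also leave open how the number responds at this position to an amine, a carboxylic acid or a longer ether chain.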